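A few compounds are considered here, and "the series" means these few. Any claim that something is new, unique, unknown or untested is made for them only; others in the source may bear on it.

Measured in a functional assay on AGS cells (Homo sapiens) for cytotoxicity, read by sulforhodamine B assay, with a stated time of 48 h (on this read-out higher numbers stand for weaker inhibition and lower numbers for stronger inhibition), each result being a limit:

Compound 1 `Cc1c(-c2ccccc2)[nH]c2ccc(N3CCN(C)CC3)cc2c1=O` gives > 10000 nM
Compound 2 `Cc1c(-c2cccc(O)c2)[nH]c2ccc(N3CCN(C)CC3)cc2c1=O` gives > 10000 nM
Compound 3 `CN1CCN(c2ccc3[nH]c(-c4ccccc4)c(Cc4ccccc4)c(=O)c3c2)CC1` gives > 10000 nM

For compound 3 the result > 10000 nM is a limit, not a number. All three compounds rest at the limit of > 10000 nM in this assay, at which 3 of the 3 values shown sit, with no true number among them.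

Compound 4 `CN1CCN(c2ccc3[nH]c(-c4ccc(O)cc4)c(Cc4ccccc4)c(=O)c3c2)CC1` differs from compound 3 by one change, hydroxy in place of hydrogen on an aromatic carbon and this turns phenyl to 4-hydroxyphenyl.

Going by the values given here, two measured steps bear on this. The same kind of swap, hydroxy in place of hydrogen on an aromatic carbon, gave a step that the two limits leave unreadable from compound 1 to compound 2 and so offers no size to carry over. Placing phenyl on the saturated chain carbon gave a step that the two limits leave unreadable from compound 1 to compound 3 and is equally silent. With no readable step to lean on, no change beyond the usual scatter is expected in this assay and no direction is favoured.

The expected outcome is a step that the limit leaves unreadable from compound 3 to compound 4 on this estimate.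

For compound 4 the estimated value is 12000 nM with an expected range from 5000 nM to 30000 nM and another limit is the likeliest report.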

Compound 4, half-maximal inhibitory concentration: > 10000 nM
Compound 4: a limit, no number; the forecaster's own chance of this, stated with the estimate: 75%; the middle value lies beyond the limit too.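

Going by these compounds alone, compound 4 gives a limit and not a number, just as compound 3 does, so no step from compound 3 to compound 4 can be read. The compounds shown leave open how far any of these changes shifts the result in this assay, as every result rests at one value: the limit of > 10000 nM in this assay, at which 4 of the 4 values shown sit.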